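Chain extension in the furan-2-carbonyl amide series

A few compounds are considered here, and "the series" means these few. Any claim that something is new, unique, unknown or untested is made for them only; others in the source may bear on it.

Compound 2 `COc1cc2nc(N(C)CCCCCCCN(C)C(=O)c3ccco3)nc(N)c2cc1OC` is the higher of the two numbers measured in a functional assay for antagonist activity at Adrenergic receptor alpha-1 (Rattus norvegicus) (on this read-out higher numbers stand for weaker binding and lower numbers for tighter binding), at 2.51 nM; compound 1 `COc1cc2nc(N(C)CCCCCN(C)C(=O)c3ccco3)nc(N)c2cc1OC` gives 1.48 nM, and the step of a 1.7-fold higher number from compound 1 to compound 2 (0.23 log units; within the scatter) is within the scatter. Compound 3 `COc1cc2nc(N(C)CCCCCCCCN(C)C(=O)c3ccco3)nc(N)c2cc1OC` extends the same chain once more: (((furan-2-yl)carbonyl)(methyl)amino)methyl in place of ((furan-2-yl)carbonyl)(methyl)amino on a saturated chain carbon, seven bonds along the chain from a nitrogen on an aromatic ring. Among the measured compounds shown here, the only measured step that bears on this kind of change is the one from compound 1 to compound 2, which also lengthened the chain and stayed within the scatter. On that basis compound 3 is expected to read close to compound 2 in this assay, with at most a slight shift towards a higher number, a 1.3-fold higher number from compound 2 to compound 3 (0.11 log units; within the scatter), not clearly beyond the scatter. The estimate for compound 3 in this assay is therefore 3.2 nM, with a range from 1.5 nM to 7 nM; a second point of this kind would be needed before any trend along the chain could be claimed.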

Compound 3, dissociation constant: 7.94 nM
The estimate for compound 3 lay 2.5-fold (0.39 log units) below the measured number; measured number above the stated range.
By their numbers in this assay, from the lowest: compounds 1 and 2 (each within the scatter of the next); then compound 3.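

In this assay, among the compounds shown here, putting (((furan-2-yl)carbonyl)(methyl)amino)methyl in place of ((furan-2-yl)carbonyl)(methyl)amino on a saturated chain carbon, seven bonds along the chain from a nitrogen on an aromatic ring, gives a 3.2-fold higher number from compound 2 to compound 3 (0.50 log units; beyond the scatter), the only step in this set beyond the scatter. The earlier extension, a 1.7-fold higher number from compound 1 to compound 2 (0.23 log units; within the scatter), stayed within the scatter, so chain length does register at this position, although the effect is modest and rests on a single pair of compounds. No evidence is available that bears on this result.

The compounds shown leave open whether a longer chain would move the number further in the same direction. They also leave open whether the same extension would give a step of this size with an amine or a carboxylic acid at the chain end in place of the furan-2-carbonyl amide.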